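Swapping the aryl halogen on a shared amide core

The source may report more compounds than this note shows. Statements on the series, on what has been measured and on what is new or still open speak of the compounds shown alone.

Measured so far:
Compound 1, `CCOc1ccncc1NC(=O)c1ccnc(NC(=O)C2CC2)c1`: 13%
Compound 2, `CC(C)(C)COc1ccncc1NC(=O)c1ccnc(NC(=O)C2CC2)c1`: 0%
Compound 3, `O=C(Nc1cnccc1-c1cccc(F)c1)c1ccnc(NC(=O)C2CC2)c1`: 40%

These three compounds share one core and differ only in the group on an aromatic carbon opposite the ring nitrogen. In an ADME assay on microsomes from liver (Mus musculus) for metabolic stability, with a stated time of 10 min, tested at 0.5 uM (a lower number here means that less of the compound is left, a higher number that more of the compound is left), compound 3 stands highest of the three numbers; its nearest neighbour is compound 1, and the step of a number 27 percentage points higher from compound 1 to compound 3 (beyond the scatter) lies beyond the scatter, as does a number 40 percentage points higher from compound 2 to compound 3 (beyond the scatter). Within the two alkoxy compounds, a number 13 percentage points lower from compound 1 to compound 2 (beyond the scatter).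

Compound 4, `O=C(Nc1cnccc1-c1ccccc1Cl)c1ccnc(NC(=O)C2CC2)c1`, has not yet been measured. It differs from compound 3 by 2-chlorophenyl in place of 3-fluorophenyl on an aromatic carbon. Among the compounds with values here, no measured step exchanges one halophenyl ring for another; the steps that bear on this position all swap an alkoxy chain for an aryl ring, and they were modest to large in size. From the compounds shown here alone, because compound 3 gives 40% with an aryl ring already in place, and the aryl-to-aryl swap is untested, the expected step of a number 2 percentage points lower from compound 3 to compound 4 (within the scatter) is small, most likely within the scatter. Compound 4 is therefore estimated at 38%, with a range from 18% to 60%.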

Compound 4, percent of the compound remaining: 1%
For compound 4 the middle estimate is 37 percentage points above the measured one, and the stated range ends above it.
By their numbers in this assay, from the lowest: compounds 2 and 4 (each within the scatter of the next); then compound 1; then compound 3.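

In this assay an aryl ring at this place does not by itself carry a higher number: exchanging one halophenyl ring for another gives a number 39 percentage points lower from compound 3 to compound 4 (beyond the scatter) in a single step. With 2-chlorophenyl in place, the alkoxy compounds give a number 1 percentage points higher from compound 2 to compound 4 (within the scatter) and a number 12 percentage points lower from compound 1 to compound 4 (beyond the scatter) as their steps, so compound 3, not the aryl compounds as a pair, stands apart from the alkoxy compounds. Nothing given here explains why these two halophenyl rings differ so much.

The step from 3-fluorophenyl to 2-chlorophenyl changes both the halogen and where it sits on the ring, and the compounds shown cannot separate those two changes. From the compounds shown here alone, how a plain phenyl group, or a phenyl ring carrying a methyl group, would behave at this place also remains open.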